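Pyridine swap on the carbonyl: compound 2 to compound 3

The source may report more compounds than this note shows. Statements on the series, on what has been measured and on what is new or still open speak of the compounds shown alone.

Measured so far in a functional assay on MCF7 cells (Homo sapiens) for antiproliferative activity, with a stated time of 5 days; a higher number here means a weaker inhibitor, a lower number a stronger inhibitor:
- compound 1 `CCCCc1ccc2[nH]c(-c3ccc(OC)cc3)c(/C=N/NC(=O)c3ccc(OC)cc3)c2c1`: 226 nM
- compound 2 `CCCCc1ccc2[nH]c(-c3ccc(OC)cc3)c(/C=N/NC(=O)c3ccncc3)c2c1`: 69 nM

Compound 2 has the lower number of the two measured compounds, at 69 nM. The next compound, compound 3 `CCCCc1ccc2[nH]c(-c3ccc(OC)cc3)c(/C=N/NC(=O)c3cccnc3)c2c1`, has pyridin-3-yl in place of pyridin-4-yl on a carbonyl carbon. Within the data shown here, only one measured step bears on this change, a 3.3-fold lower number from compound 1 to compound 2 (0.52 log units; beyond the scatter). That modest step put pyridin-4-yl in place of 4-methoxyphenyl at the same carbonyl carbon, so it shows that this site can shift the number in this assay. Among the measured compounds shown here, it is a larger structural change than the one now in view, and no measured pair compares pyridin-3-yl with pyridin-4-yl. A smaller step is therefore expected, probably none beyond the scatter, with a slight lean towards a higher number as a tentative guess. The expected change is a 1.4-fold higher number from compound 2 to compound 3 (0.14 log units; within the scatter). For compound 3 the estimated value is 95 nM, with an expected range of 40 nM to 230 nM.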

Compound 3, half-maximal inhibitory concentration: 75 nM
For compound 3 the middle estimate is 1.3-fold (0.10 log units) above the measured one; the measured number falls inside the stated range.
By their numbers in this assay, from the lowest: compounds 2 and 3 (each within the scatter of the next); then compound 1.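

In this assay, pyridin-3-yl in place of pyridin-4-yl on the carbonyl carbon gives a 1.1-fold higher number from compound 2 to compound 3 (0.04 log units; within the scatter) and so leaves the number unresolved from that of compound 2: at this site, the two pyridine isomers cannot be told apart in this readout. The comparison with the 4-methoxyphenyl group now rests on two pyridines rather than one, since a 3.0-fold lower number from compound 1 to compound 3 (0.48 log units; beyond the scatter) runs in the same direction as a 3.3-fold lower number from compound 1 to compound 2 (0.52 log units; beyond the scatter) and the lower number is therefore not unique to pyridin-4-yl. No measured property of these groups accompanies the numbers, and the data give no account of the difference between the pyridines and 4-methoxyphenyl.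

On these data alone, it remains open whether pyridin-2-yl, a saturated piperidin-4-yl or a phenyl ring carrying a carboxylic acid on the same carbonyl carbon would stay with the two pyridines or return towards compound 1. As far as these compounds go, all three compounds also share the butyl chain and the 4-methoxyphenyl group on the shared core, so the effect of a shorter chain or an amine at either place is unknown.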